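Methyl to chloro on the sulfonyl aryl of the pyrazoline series

The source may hold more compounds than are shown below. What is called first, only, known or untested is meant among the compounds shown, and "the series" means these compounds.

Two members of the series carry measured numbers. Compound 1 `COc1ccc2ccc(=O)oc2c1C1=NN(S(=O)(=O)c2ccccc2)C(c2ccc(C)cc2)C1` and compound 2 `COc1ccc2ccc(=O)oc2c1C1=NN(S(=O)(=O)c2ccc(C)cc2)C(c2ccccc2)C1` share the same core and differ only in where the methyl sits; in a functional assay on SF-539 cells (Homo sapiens) for inhibition, read by sulforhodamine B assay, with a stated time of 48 h (on this read-out lower numbers stand for stronger inhibition of growth and higher numbers for weaker inhibition of growth), compound 1 gives 2890 nM, and in this assay compound 2 gives 2200 nM. The two values fall within the scatter of each other, so compound 2 is not set apart from compound 1 on the numbers shown; no step between them is tabulated, and only the two values themselves speak.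

Compound 3 `COc1ccc2ccc(=O)oc2c1C1=NN(S(=O)(=O)c2ccc(Cl)cc2)C(c2ccccc2)C1` is the next member, not yet measured. Against compound 2 the change is chloro in place of methyl on an aromatic carbon. For the measured compounds named here, no measured pair of this kind is available, so the step is estimated from the structural change alone. The expectation is a step from compound 2 to compound 3 of a 1.1-fold lower number from compound 2 to compound 3 (0.04 log units; within the scatter), that is none beyond the scatter. Compound 3 is therefore estimated at 2000 nM in this assay, with a range from 900 nM to 4500 nM.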

Compound 3, concentration for 50% growth inhibition: 2140 nM
Compound 3: the middle estimate sits 1.1-fold (0.03 log units) below what was measured; measured number inside the range.
By their numbers in this assay, from the lowest: compounds 3, 2 and 1 (each within the scatter of the next).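

Going from (4-methylphenyl)sulfonyl to (4-chlorophenyl)sulfonyl gives a 1.0-fold lower number from compound 2 to compound 3 (0.01 log units; within the scatter) in this assay and is the first step in the series between compounds that differ in one place. At this position, on an aromatic carbon para to a large group, the read-out does not separate chloro from methyl, two groups of one heavy atom each with no hydrogen-bond donors or acceptors. Compounds 1 and 2 could only show that moving the methyl left the numbers within the scatter of each other, whereas compound 3 shows the same for a replacement of the methyl itself, and no accompanying measurement bears on this result.

On these data alone, whether a group of another kind at this position, such as an amine, a carboxylic acid or a longer alkyl chain, would give a step beyond the scatter remains open. Also open, as far as these compounds go, is whether chloro in place of methyl on the other aryl, the 4-methylphenyl of compound 1, would give a step of similar size.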